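The source may hold more compounds than are shown below. What is called first, only, known or untested is meant among the compounds shown, and "the series" means these compounds.

Measured compounds:
- compound 1, `COc1ccc(C(O)(c2cc3cc([N+](=O)[O-])cc(-c4ccccc4)c3o2)c2cncn2C)cc1`: 4970 nM
- compound 2, `Cc1cccc(-c2cc([N+](=O)[O-])cc3cc(C(O)(c4ccc(C#N)cc4)c4cncn4C)oc23)c1`: 23.2 nM

Both compounds were tested in a functional assay on QG-56 cells (Homo sapiens) for antiproliferative activity; on this read-out lower numbers stand for stronger inhibition and higher numbers for weaker inhibition. Compound 1 gives 4970 nM, the highest of the two numbers, meaning the weaker inhibition; compound 2 gives 23.2 nM, a far lower number, and that gap lies well beyond the usual scatter. The two compounds differ in several places at once, so nothing can be read into any single change between them.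

Compound 3, `Cn1cncc1C(O)(c1ccc(C(=O)O)cc1)c1cc2cc([N+](=O)[O-])cc(-c3ccccc3)c2o1`, has not yet been tested in this assay. It is derived from compound 1 by one change: carboxy in place of methoxy on an aromatic carbon. Among the compounds with values here, the change exchanges one small uncharged group for another on the same aromatic carbon; there is no measured pair showing what such an exchange does here, so the expectation is uncertain. For compound 3 the step from compound 1 is expected to be small, most likely none beyond the scatter, with a 1.2-fold higher number from compound 1 to compound 3 (0.08 log units; within the scatter). Compound 3 is therefore estimated at 6000 nM, within a range of 1200 nM to 30000 nM.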

Compound 3, half-maximal inhibitory concentration: > 10000 nM
Compound 3 ended at the assay's limit (the forecaster's own chance of this, stated with the estimate: 15%); middle value at least 1.6-fold (0.22 log units) from the limit.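

In this assay, compound 3 gives > 10000 nM, which is a limit of the assay and not a number. Within the data shown here, this gives the first one-place comparison: carboxy in place of methoxy, para to a large group, produces an at least 2.0-fold higher number from compound 1 to compound 3 (0.30 log units; that floor lies within the scatter), so the swap brings no gain in inhibition, but the floor alone does not establish a real loss. The true size of the step cannot be read, and whether it goes beyond the scatter stays unknown: the limit of > 10000 nM in this assay, at which 1 of the 3 values shown sits.

Still open, going by these compounds, is how other groups at this position would compare, such as an amine or a methyl ester, which would show whether the result is specific to carboxy. Also open, on these data alone, is what a nitrile would do here on the core of compound 1, with nothing else changed.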